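From sec-butyl to cyclopentyl on a sulfonamide nitrogen

The source may report more compounds than this note shows. Statements on the series, on what has been measured and on what is new or still open speak of the compounds shown alone.

Compound 1 `CCC(C)NS(=O)(=O)c1ccc(F)c(C(=O)NCc2ccc(F)c(F)c2)c1`: > 50000 nM
Compound 2 `O=C(NCc1ccccc1)c1ccc(Cl)c(S(=O)(=O)N2CCCCCC2)c1`: > 50000 nM

Both compounds were tested in an ADME assay on AML-12 cells (Mus musculus) for cytotoxicity, read by MTT assay, with a stated time of 48 h; on this read-out lower numbers stand for higher toxicity in this test and higher numbers for lower toxicity in this test. In this assay compound 1 gives > 50000 nM, which is a limit of the assay and not a number. Compound 2 gives > 50000 nM, which is likewise a limit. Compound 1 therefore stands at the limit of > 50000 nM in this assay, at which 2 of the 2 values shown sit.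

Compound 3 `O=C(NCc1ccc(F)c(F)c1)c1cc(S(=O)(=O)NC2CCCC2)ccc1F` has not yet been measured. Its structure departs from that of compound 1 by cyclopentyl in place of sec-butyl on a sulfonamide nitrogen, with cyclopentyl in place of sec-butyl on a sulfonamide nitrogen. Among the measured compounds shown here, no step between measured compounds is available, so the size of this change has no direct precedent. The expectation rests on compound 1 and its limit of > 50000 nM. No shift in either direction beyond the usual scatter is expected in this assay, and a further limit is the likeliest report. The expected step, a step that the limit leaves unreadable from compound 1 to compound 3, is estimated to stay within that scatter. For compound 3 the estimated value is 60000 nM, with an expected range from 25000 nM to 120000 nM.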

Compound 3, half-maximal cytotoxic concentration: > 50000 nM
Compound 3 ended at the assay's limit; the forecaster's own chance of this, stated with the estimate: 85%; the middle value does not contradict the limit.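

In this assay, among the compounds shown here, compound 1 and compound 3 both end at a limit and not a number, so no step between them can be read. Every value shown is such a limit: the limit of > 50000 nM in this assay, at which 3 of the 3 values shown sit.

The compounds shown leave open whether cyclopentyl and sec-butyl on a sulfonamide nitrogen differ at all in this test, and at what concentration, if any, compound 1 or compound 3 would reach half-maximal cytotoxicity.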